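The compounds below may be only part of what the source reports. "The series", "measured", "known", "first", "only" and "open" are said of these compounds alone.

Compound 1 `CC(C)(C)[C@@H](O)C(=O)N1OCC[C@H]1C(=O)NCc1cc(Cl)ccc1-n1cnnn1`: < 12 mL.min-1.g-1
Compound 2 `O=C(NCc1cc(Cl)ccc1-n1cnnn1)[C@@H]1CCON1C(=O)[C@H](O)c1ccccc1`: < 12 mL.min-1.g-1

In an ADME assay on liver for metabolic stability, with Liver microsome (Homo sapiens) as the target, read by LC-MS, using microsomes (a lower number here means slower removal, a higher number faster removal of the compound), compound 2 stands at < 12 mL.min-1.g-1, which is a limit of the assay and not a number. Compound 1 shares that result, so both compounds sit at the limit of < 12 mL.min-1.g-1 in this assay, at which 2 of the 2 values shown sit. Compound 3 `CC(C)(C)C[C@@H](O)C(=O)N1OCC[C@H]1C(=O)NCc1cc(Cl)ccc1-n1cnnn1` has neopentyl in place of phenyl on a saturated chain carbon bound to a carbonyl carbon and an oxygen on a saturated carbon. For the measured compounds named here, the only measured step that bears on this change is a step that the two limits leave unreadable from compound 1 to compound 2, so it gives no size to carry over. No step beyond the scatter is therefore expected, and compound 3 is expected to stay close to that limit. The expected step is a number no lower from compound 2 to compound 3 (the limit leaves the size open). The estimate for compound 3 is 12 mL.min-1.g-1, with an expected range of 7 mL.min-1.g-1 to 28 mL.min-1.g-1.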

Compound 3, intrinsic clearance in microsomes: < 12 mL.min-1.g-1
Compound 3: no number, only a limit; the forecaster's own chance of this, stated with the estimate: 60%; the middle value lies on the limit itself.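

Compound 3, like compound 1 and compound 2, gives only a limit and not a number in this assay, so no step among these compounds can be read. As far as these compounds go, how far apart their true clearances lie remains open.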